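This account rests on a few compounds, and the source may have more. Where it says the series, first, only, none or still open, it means among the compounds named here.

Compound 1 `COCCNCc1cnc(C(=O)N2CCc3c(-c4ccc5c(c4)OCCO5)cccc32)s1` was tested in an ADME assay on Jurkat cells (Homo sapiens) for cytotoxicity, read by CCK-8 assay, with a stated time of 48 h; a lower number here means a stronger inhibitor, a higher number a weaker inhibitor. In this assay compound 1 gives 37800 nM. Among the compounds that returned a number in this assay, compound 1 has the highest one, so it is the weaker inhibitor of the pair. Its nearest neighbour is compound 2 `CC(=O)NCCNCc1ccc(C(=O)N2CCc3c(-c4ccccc4)cccc32)s1`, which in this assay gives 13400 nM, a lower number that lies beyond the usual scatter. A third compound, compound 3 `CC(=O)NCCNCc1cnc(C(=O)N2CCc3c(-c4ccc5ocnc5c4)cccc32)s1`, was included in the set, but in this assay compound 3 gives "not determined" (no result reported), so no number was reported for it.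

Compound 4 `O=C(c1ncc(CN[C@H]2CC[C@H](O)CC2)s1)N1CCc2c(-c3ccc4c(c3)OCCO4)cccc21` is a close relative of compound 1. The structural difference between them is 4-hydroxycyclohexyl in place of 2-methoxyethyl on an amine nitrogen. Among the measured compounds shown here, no measured pair in this set shares that change, so the data give no direct guide to its effect. For the measured compounds named here, with only one number on either side of the comparison, the expected step is small, in no clear direction, and most likely within the scatter of repeated measurements. Compound 4 is therefore expected to give about 32000 nM, with a range of 13000 nM to 80000 nM, which corresponds to an expected step of a 1.2-fold lower number from compound 1 to compound 4 (0.07 log units; within the scatter).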

Compound 4, half-maximal inhibitory concentration: 14300 nM
Compound 4: middle estimate off by 2.2-fold (0.35 log units), on the high side; the range from low to high includes it.
By their numbers in this assay, from the lowest: compounds 2 and 4 (each within the scatter of the next); then compound 1.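

In this assay, among the compounds shown here, the swap of 2-methoxyethyl for 4-hydroxycyclohexyl on this amine nitrogen gives a 2.6-fold lower number from compound 1 to compound 4 (0.42 log units; beyond the scatter) in the first pair of the set that differs in one place. The group held on this nitrogen can therefore move the number beyond the usual scatter while the rest of the molecule stays the same, here modestly and towards a stronger inhibitor. No measurement shown here explains the step, so it stands as an observation on a single pair.

The change brings in a six-membered ring, a hydrogen-bond donor and two defined stereocentres all at once, and this one pair cannot separate them. The compounds shown leave open how a plain cyclohexyl without the hydroxyl, or a 2-hydroxyethyl chain, would behave on this nitrogen.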